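The compounds below may be only part of what the source reports. "The series", "measured", "known", "first", "only" and "open" are said of these compounds alone.

In an ADME assay on HEK293 cells (Homo sapiens) for cytotoxicity, read by CellTiter-Glo and resazurin assay, with a stated time of 72 h (on this read-out lower numbers stand for an effect already at smaller amounts and higher numbers for an effect only at larger amounts of compound), compound 3, with the structure `CC(C)N(Cc1cccc(OCCCCCC(=O)O)c1)C(=O)c1ccc(-c2ccc3c(c2)OCCO3)cc1`, gives only a limit of the assay, > 21900 nM, and no number. The two other values shown are limits as well. Compound 1, `CC(C)N(Cc1cccc(OCCCCCC(=O)O)c1)C(=O)c1ccc(-c2cccc(-c3ccccc3)c2)cc1`, gives in this assay the limit > 26000 nM. Compound 2, `COc1cccc(-c2ccc(C(=O)N(Cc3cccc(OCCCCCC(=O)O)c3)C(C)C)cc2)c1`, gives in this assay the limit > 20900 nM. So compound 3 stands with the others at a limit, as the limit of > 21900 nM in this assay, at which 1 of the 3 values shown sits, shows for it, and none of the three can be placed above or below another.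

Compound 4 has the structure `CC(C)N(Cc1cccc(OCCCCCC(=O)O)c1)C(=O)c1ccc(-c2cccc(S(C)(=O)=O)c2)cc1`. The change from compound 3 is 3-(methylsulfonyl)phenyl in place of 2,3-dihydro-1,4-benzodioxin-6-yl on an aromatic carbon. The measured steps that might bear on it, a step that the two limits leave unreadable from compound 1 to compound 2, a step that the two limits leave unreadable from compound 1 to compound 3 and a step that the two limits leave unreadable from compound 2 to compound 3, each end at a limit on both sides, so their size is not readable, and no step beyond the scatter can be expected for this assay from them alone.

The step from compound 3 to compound 4 is therefore estimated at a step that the limit leaves unreadable from compound 3 to compound 4. Compound 4 is expected to give about 30000 nM in this assay, most likely again as a limit, between 10000 nM and 100000 nM.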

Compound 4, half-maximal effective concentration: > 26000 nM
Compound 4 was reported as a limit (the forecaster's own chance of this, stated with the estimate: 80%); the middle value does not contradict the limit.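

Going by these compounds alone, compound 4 gives only a limit in this assay, as do compounds 1, 2 and 3, so no step between compound 4 and any of them can be read. The compounds shown leave open at what concentration any of them would affect these cells, and whether exchanging these groups changes that concentration at all.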